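A Furan Amide in Place of a Bromophenyl Amide

A few compounds are considered here, and "the series" means these few. Any claim that something is new, unique, unknown or untested is made for them only; others in the source may bear on it.

Compound 1, `Cc1cc(C(=O)Nc2cccc(-c3ccnc4c(N)cccc34)c2)ccc1Br`, gives 9900 nM. Compound 2, `Nc1cccc2c(-c3cccc(NC(=O)c4ccc(Cl)cc4C(F)(F)F)c3)ccnc12`, reaches only the assay limit of > 20000 nM. Compound 3, `CC(=O)Nc1cccc2c(-c3cccc(NC(=O)c4ccc(Br)c(C)c4)c3)ccnc12`, reaches only the assay limit of > 20000 nM.

In a functional assay on A375P cells (Homo sapiens) for antiproliferative activity, read by MTT assay, with a stated time of 48 h (a lower number here means a stronger inhibitor, a higher number a weaker inhibitor), compound 3 therefore stands at the limit of > 20000 nM in this assay, at which 2 of the 3 values shown sit, and an at least 2.0-fold higher number from compound 1 to compound 3 (0.30 log units; that floor lies within the scatter) ends at that limit rather than at a number. Compound 4, `CC(=O)Nc1cccc2c(-c3cccc(NC(=O)c4cc(C)oc4C)c3)ccnc12`, differs from compound 3 by 2,5-dimethylfuran-3-yl in place of 4-bromo-3-methylphenyl on a carbonyl carbon. Among the measured compounds shown here, no measured pair isolates this change on the carbonyl carbon; compounds 1 and 2 differ in more than one place, and their two values say nothing about it. The step that the limit leaves unreadable from compound 3 to compound 4 is thus expected to stay within the scatter, with another limit the likely outcome. Compound 4 is estimated at 25000 nM, in the range 8000 nM to 80000 nM.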

Compound 4, half-maximal inhibitory concentration: > 20000 nM
Compound 4: only a limit was reported (the forecaster's own chance of this, stated with the estimate: 70%); the middle value lies beyond the limit too.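

Compound 3 and compound 4 both end at a limit rather than a number in this assay, so the step between them cannot be read: the limit of > 20000 nM in this assay, at which 3 of the 4 values shown sit. The compounds shown leave open whether 2,5-dimethylfuran-3-yl and 4-bromo-3-methylphenyl on the carbonyl carbon differ at all in this measurement.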